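Sulfonyl aryl swap in a series of weak inhibitors

The compounds below may be only part of what the source reports. "The series", "measured", "known", "first", "only" and "open" are said of these compounds alone.

Working notes. The series is followed in an assay on HEK293 cells for inhibition of prostaglandin E2 receptor EP2 subtype (Rattus norvegicus); on this read-out higher numbers stand for weaker inhibition and lower numbers for stronger inhibition. Compound 1 `CC(C)(C)c1ccc(CN(Cc2cccc(CCC(=O)O)c2)S(=O)(=O)c2ccc(Cl)cc2)cc1` returns only a limit of the assay, > 3200 nM. Compound 2 `CCCCCC(O)CCCN(CCCCC(=O)O)S(C)(=O)=O` likewise returns only a limit, > 3200 nM. Among the compounds with values here, compound 3 `CCCCc1ccc(CN(CCCCOCC(=O)O)S(C)(=O)=O)cc1` is the one compound with a number, 701 nM. Compound 1 thus stands at the limit of > 3200 nM in this assay, at which 2 of the 3 values shown sit. Compound 4 `CC(C)(C)c1ccc(CN(Cc2cccc(CCC(=O)O)c2)S(=O)(=O)c2ccccn2)cc1` differs from compound 1 in one place: pyridin-2-yl in place of 4-chlorophenyl on a sulfonyl sulfur. Within the data shown here, no measured pair in the set shares this change, so the series itself gives no size for it. The expected step is a step that the limit leaves unreadable from compound 1 to compound 4, none beyond the scatter. Compound 4 is expected at 4000 nM, ranging from 1000 nM to 16000 nM, and most likely the assay will again report only a limit for compound 4.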

Compound 4, half-maximal inhibitory concentration: 52 nM
For compound 4 the middle estimate is 77-fold (1.89 log units) above the measured one, and the stated range ends above it.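

In this assay, pyridin-2-yl in place of 4-chlorophenyl on a sulfonyl sulfur gives an at least 61-fold lower number from compound 1 to compound 4 (1.78 log units; beyond the scatter). Within the data shown here, this position can therefore carry the core of compound 1 from a limit to a measured value with one swap, which the earlier compounds could not show. The step has only a lower bound, because the value of compound 1 is a limit and not a number: the limit of > 3200 nM in this assay, at which 2 of the 4 values shown sit.

The swap removes the chlorine and brings in the ring nitrogen together, so this pair cannot separate the two. An unsubstituted phenyl on the same sulfur would be needed to tell them apart.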